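Solubility of a bicyclic amide in place of a methylamide

The source may hold more compounds than are shown below. What is called first, only, known or untested is meant among the compounds shown, and "the series" means these compounds.

Measured compounds:
Compound 2, `CNC(=O)c1cc(C(=O)NC)c2c(c1)[C@](C)(c1ccccc1)CO2` — >= 132 ug/mL
Compound 1, `CNC(=O)c1cc(C(=O)N[C@H]2[C@@H]3COC[C@@H]32)cc2c1OC[C@H]2c1cccnc1` — >= 104 ug/mL

In a physicochemical assay for solubility (on this read-out lower numbers stand for lower solubility and higher numbers for higher solubility), compound 2 gives >= 132 ug/mL, which is a limit of the assay and not a number. Going by the values given here, compound 1, the only other compound measured here, also sits at a limit, >= 104 ug/mL, as the evidence the limit of >= 104 ug/mL in this assay, at which 1 of the 2 values shown sits, and the limit of >= 132 ug/mL in this assay, at which 1 of the 2 values shown sits, records. Among the compounds with values here, compound 2 therefore stands at the upper limit of this assay, with no measured step to any other compound to draw on.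

Compound 3, `CNC(=O)c1cc(C(=O)N[C@H]2[C@@H]3COC[C@@H]32)cc2c1OC[C@@]2(C)c1ccccc1`, has not yet been measured in this assay. It differs from compound 2 by a group of 6 heavy atoms (5 carbon, 1 oxygen; one three-membered non-aromatic ring of carbon only, one five-membered non-aromatic ring with 1 hetero atom) in place of one carbon atom, on an amide-type nitrogen. Since compound 1 carries the same bicyclic ether group on its amide nitrogen and still sits at a limit, compound 3 is expected to remain soluble, with a step of an at least 1.4-fold lower number from compound 2 to compound 3 (0.16 log units; that floor lies within the scatter) that is estimated to be small, and possibly within the scatter. The estimate for compound 3 in this assay is 90 ug/mL, with a range from 30 ug/mL to 160 ug/mL.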

Compound 3, solubility: >= 147 ug/mL
Compound 3: only a limit was reported; the forecaster's own chance of this, stated with the estimate: 40%; middle value at least 1.6-fold (0.21 log units) from the limit.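

In this assay compound 3 gives >= 147 ug/mL, a limit of the assay and not a number. Compound 2 gives >= 132 ug/mL, also a limit, so the step between compound 2 and compound 3 cannot be read. The compounds shown leave open what replacing the methyl on the amide-type nitrogen does to solubility.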